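Unbound fraction: fluoro in place of methoxy

A few compounds are considered here, and "the series" means these few. Any claim that something is new, unique, unknown or untested is made for them only; others in the source may bear on it.

Measured in an ADME assay on a cell-free system (plasma, Homo sapiens) for protein binding, using equilibrium dialysis, with a stated time of 5 h, tested at 10 uM; a higher number here means a larger unbound share of the compound, a lower number a smaller unbound share
- compound 1 `CC[C@H](c1ccc(C(=O)O)c(Oc2cccc(Cl)c2)c1F)N1CCC[C@H](n2cc(C)c(=O)[nH]c2=O)C1` gives < 0.01 (a limit of the assay)
- compound 2 `CCC[C@H](c1ccc(C(=O)O)c(Oc2cccc(Cl)c2)c1OC)N1CCC[C@H](n2cc(C)c(=O)[nH]c2=O)C1` gives 0.034

Going by the values given here, compound 2 holds the only true number, at 0.034. The value of compound 1 is a limit of the assay. The next compound to be measured is compound 3 `CCC[C@H](c1ccc(C(=O)O)c(Oc2cccc(Cl)c2)c1F)N1CCC[C@H](n2cc(C)c(=O)[nH]c2=O)C1`, which carries fluoro in place of methoxy on an aromatic carbon, ortho to a 3-chlorophenoxy group and meta to a carboxy group (fluoro in place of methoxy on an aromatic carbon). Among the compounds with values here, no measured pair shows this change on its own. A lower reading in this assay is nevertheless expected, resting on compound 1 at the limit < 0.01, which also bears fluoro on that carbon. The expected step is a 2.6-fold lower number from compound 2 to compound 3 (0.42 log units; beyond the scatter), a little beyond the scatter. For compound 3 the estimate is 0.013, with an expected range from 0.006 to 0.028. A report as a limit alone would not be surprising.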

Compound 3, unbound fraction: < 0.01
Compound 3 ended at the assay's limit (the forecaster's own chance of this, stated with the estimate: 40%); at least 1.3-fold (0.11 log units) between middle value and limit.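

In this assay, fluoro in place of methoxy on the aromatic carbon ortho to a 3-chlorophenoxy group now has a comparison that differs in one place only, giving an at least 3.4-fold lower number from compound 2 to compound 3 (0.53 log units; beyond the scatter). Going by these compounds alone, compound 1 also carries fluoro there but differs from compound 2 in more than one place, so only this pair ties the lower number to this change alone. The step from compound 1 to compound 3 cannot be read, and the full size of the step from methoxy to fluoro stays hidden at the low end: the limit of < 0.01 in this assay, at which 2 of the 3 values shown sit.

Still open, going by these compounds, is how other groups on this carbon, such as hydroxy, an amine or a nitrile, would compare with methoxy. It is also unknown whether a shorter or longer chain would shift the unbound share with methoxy kept in place.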